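This account rests on a few compounds, and the source may have more. Where it says the series, first, only, none or still open, it means among the compounds named here.

Measured compounds in a functional assay on MDA-MB-468 cells (Homo sapiens) for antiproliferative activity, read by MTT assay, with a stated time of 72 h; a lower number here means a stronger inhibitor, a higher number a weaker inhibitor:
Compound 1 `O=C(Nc1ccc(Cl)c(-c2nnc3c(Cl)cccn23)c1)c1cccnc1` gives > 100000 nM, which is a limit of the assay.
Compound 2 `O=C(Nc1ccc(Cl)c(-c2nnc3c(Cl)cccn23)c1)c1ccc(C(F)(F)F)cc1F` gives 22300 nM.
Compound 3 `Cc1cc(Cl)ccc1C(=O)Nc1ccc(Cl)c(-c2nnc3c(Cl)cccn23)c1` gives 34300 nM.

Compound 1 stands at the assay limit (the limit of > 100000 nM in this assay, at which 1 of the 3 values shown sits), so no number is known for it. Compound 4 `O=C(Nc1ccc(Cl)c(-c2nnc3c(Cl)cccn23)c1)c1cccnc1Cl` differs from compound 1 by chloro in place of hydrogen on an aromatic carbon. Among the measured compounds shown here, the one measured step from compound 1 is an at least 2.9-fold lower number from compound 1 to compound 3 (0.46 log units; beyond the scatter), a change of the whole ring rather than a single substituent, so it bears only loosely on compound 4. Compounds 2 and 3 show that halogen-bearing aryl amides on the shared core reach the measurable range. A step of about an at least 1.2-fold lower number from compound 1 to compound 4 (0.09 log units; that floor lies within the scatter) is expected, though because compound 1 sits at a limit of > 100000 nM in this assay, at which 1 of the 3 values shown sits, its true size is uncertain. Compound 4 is estimated at 80000 nM, with a range from 30000 nM to 200000 nM.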

Compound 4, half-maximal inhibitory concentration: > 100000 nM
Compound 4 ended at the assay's limit; the forecaster's own chance of this, stated with the estimate: 45%; at least 1.2-fold (0.09 log units) between middle value and limit.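

Chloro on this position, next to the ring nitrogen, leaves the pyridin-3-yl amide at the limit in this assay, so a single chlorine here does not bring this amide into the measurable range. The step between compound 1 and compound 4 cannot be read, since both compounds sit at a limit: the limit of > 100000 nM in this assay, at which 2 of the 4 values shown sit. The change from 4-chloro-2-methylphenyl to 2-chloropyridin-3-yl gives an at least 2.9-fold higher number from compound 3 to compound 4 (0.46 log units; beyond the scatter).

Going by these compounds, whether an amine or a methoxy group on this carbon would give a measurable value remains open. On these data alone, the true values of compound 1 and compound 4 also remain unknown.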